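Removing the carboxypiperidine group from compound 3

This account rests on a few compounds, and the source may have more. Where it says the series, first, only, none or still open, it means among the compounds named here.

Values so far in an ADME assay on HEK293 cells (Homo sapiens) for cytotoxicity, read by CCK-8 assay, with a stated time of 48 h (on this read-out lower numbers stand for stronger inhibition and higher numbers for weaker inhibition), follow
Compound 1 `COc1ccc(/C=C\c2cc(OC)c(OC)c(OC)c2)cc1OCc1ccc(CNC(C)(C)C(=O)O)cc1` gives > 50000 nM as a limit
Compound 2 `COc1ccc(/C=C\c2cc(OC)c(OC)c(OC)c2)cc1OCc1ccc(CN2CCCC[C@@H]2C(=O)O)cc1` gives 42000 nM as a number
Compound 3 `COc1ccc(/C=C\c2cc(OC)c(OC)c(OC)c2)cc1OCc1ccc(CN2CCCCC2C(=O)O)cc1` gives > 50000 nM as a limit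

Compound 3 stands at the limit of > 50000 nM in this assay, at which 2 of the 3 values shown sit, and holds only a limit. Compound 4 `COc1ccc(/C=C\c2cc(OC)c(OC)c(OC)c2)cc1OCc1ccc(CO)cc1` differs from it in one place hydroxy in place of 2-carboxypiperidin-1-yl on a saturated chain carbon bound to an aromatic carbon and has not yet been measured. The measured steps are small or unreadable: an at least 1.1-fold lower number from compound 1 to compound 2 (0.07 log units; that floor lies within the scatter) and an at least 1.1-fold higher number from compound 2 to compound 3 (0.07 log units; that floor lies within the scatter) stay within the scatter, and a step that the two limits leave unreadable from compound 1 to compound 3 cannot be sized. None of them removes the 2-carboxypiperidin-1-yl group, so they set no size for this change. Starting from a limit, a move toward lower numbers is expected, though its size is uncertain. The expected change is an at least 5.0-fold lower number from compound 3 to compound 4 (0.69 log units; beyond the scatter) as an estimate. Compound 4 is expected at 10000 nM in this assay, with an estimated range from 500 nM to 50000 nM overall.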

Compound 4, half-maximal inhibitory concentration: 37000 nM
Compound 4: the middle estimate sits 3.7-fold (0.57 log units) below what was measured, within the range that was stated.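

In this assay, hydroxy in place of 2-carboxypiperidin-1-yl on a saturated chain carbon bound to an aromatic carbon gives a 1.1-fold lower number from compound 2 to compound 4 (0.06 log units; within the scatter), so a group without a ring, nitrogen or carboxylic acid reads the same here as the defined compound 2. The comparisons with the two compounds held only as limits give an at least 1.3-fold lower number from compound 3 to compound 4 (0.13 log units; that floor lies within the scatter) and an at least 1.3-fold lower number from compound 1 to compound 4 (0.13 log units; that floor lies within the scatter), and neither floor shows a real shift. What a simple amine or a longer chain ending in a carboxylic acid would give at this place stays open, as does the true size of those two steps: the limit of > 50000 nM in this assay, at which 2 of the 4 values shown sit.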